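Thiophene-fused core: pyridyl to cyclopropyl swap

The compounds below may be only part of what the source reports. "The series", "measured", "known", "first", "only" and "open" are said of these compounds alone.

Working notes on a small series of agonists at a functional assay on cells for agonist activity at Free fatty acid receptor 1 (Rattus norvegicus), read by FLIPR and calcium flux; on this read-out lower numbers stand for an effect already at smaller amounts and higher numbers for an effect only at larger amounts of compound. Two compounds share a common core and differ in the group on the fused thiophene. Compound 1 (`CC#C[C@@H](Cc1nnn[nH]1)c1ccc(OCc2ccc3scc(-c4cccnc4C)c3c2)cc1`) gives 20 nM in this assay. Compound 2 (`CC#C[C@@H](Cc1nnn[nH]1)c1ccc(OCc2ccc3sc(C(F)(F)F)c(-c4ccc(OCCOC)cc4C)c3c2)cc1`) gives 14 nM in this assay. The two numbers lie within the scatter of each other, so compound 1 and compound 2 cannot be told apart on these data; compound 1 simply carries the larger of the two numbers.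

Compound 3 (`CC#C[C@@H](Cc1nnn[nH]1)c1ccc(OCc2ccc3scc(C4CC4)c3c2)cc1`) has not yet been measured. It differs from compound 1 in one place: cyclopropyl in place of 2-methylpyridin-3-yl on an aromatic carbon. Within the data shown here, no measured pair of this kind exists, so the expectation rests on the single value of compound 1, 20 nM. A moderate weakening is expected, beyond the scatter, as a 3.5-fold higher number from compound 1 to compound 3 (0.54 log units; beyond the scatter). Compound 3 is estimated at 70 nM, with a range from 20 nM to 250 nM.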

Compound 3, half-maximal effective concentration: 239 nM
Compound 3: middle estimate off by 3.4-fold (0.53 log units), on the low side; low and high end bracket the measured number.
By their numbers in this assay, from the lowest: compounds 2 and 1 (each within the scatter of the next); then compound 3.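

In this assay, among these compounds, the group on this aromatic carbon, two ring bonds from the ring sulfur, matters: cyclopropyl in place of 2-methylpyridin-3-yl gives a 12-fold higher number from compound 1 to compound 3 (1.08 log units; beyond the scatter), a large step and the first reading of a single change. This one change replaces a six-membered aromatic ring carrying a hydrogen-bond acceptor with a smaller three-membered non-aromatic ring of carbon only, so these differences cannot be separated here. No measurement available bears on why the number rises.

The compounds shown leave open which of these differences accounts for the step. A plain phenyl ring or an isopropyl group at the same place would help to separate ring size, aromatic character and the ring nitrogen.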